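The source may hold more compounds than are shown below. What is called first, only, known or untested is meant among the compounds shown, and "the series" means these compounds.

Compound 3 `CCN(CC)C(=O)c1cncc(-c2cccc(C(=O)N[C@H]3CN[C@@H](C(=O)Nc4ccc(Cl)c(C(F)(F)F)c4)C3)c2)c1` carries the same pair of aryl groups as compound 2 `CCN(CC)C(=O)c1cncc(-c2cccc(C(=O)N[C@@H](C)C(=O)Nc3ccc(Cl)c(C(F)(F)F)c3)c2)c1`, but the linker between the two amides differs; the difference between the two cores is not broken down here. In a functional assay on K562 cells (Homo sapiens) for inhibition, read by MTT assay, with a stated time of 48 h (a lower number here means a stronger inhibitor, a higher number a weaker inhibitor), compound 2 gives 29900 nM, and in this assay compound 3 gives 24900 nM. Compound 1 `C[C@H](NC(=O)c1cccc(-c2cncc(C(=O)NC3CC3)c2)c1)C(=O)Nc1ccc(Cl)c(C(F)(F)F)c1` is related to compound 2 by one change, (cyclopropylamino in place of diethylamino on a carbonyl carbon). In this assay compound 1 gives 15100 nM, so the step is a 2.0-fold lower number from compound 2 to compound 1 (0.30 log units; within the scatter). Compound 4 `O=C(NC1CC1)c1cncc(-c2cccc(C(=O)N[C@H]3CN[C@@H](C(=O)Nc4ccc(Cl)c(C(F)(F)F)c4)C3)c2)c1` is made from compound 3 by the same change, (cyclopropylamino in place of diethylamino on a carbonyl carbon), at a place described in identical words. For the measured compounds named here, because the one measured instance of this change, a 2.0-fold lower number from compound 2 to compound 1 (0.30 log units; within the scatter), moved the number only a little, compound 4 is expected to land close to compound 3, with an estimated step of a 1.9-fold lower number from compound 3 to compound 4 (0.28 log units; within the scatter). For compound 4 the expected value in this assay is therefore 13000 nM, estimated to fall between 6000 nM and 28000 nM.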

Compound 4, half-maximal inhibitory concentration: 27300 nM
For compound 4 the middle estimate is 2.1-fold (0.32 log units) below the measured one; the measured number falls inside the stated range.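

In this assay, cyclopropylamino in place of diethylamino on a carbonyl carbon gives a 1.1-fold higher number from compound 3 to compound 4 (0.04 log units; within the scatter), a step that lies within the scatter. Set beside the earlier step, the two cores do not separate for this change: the same change on two cores in this assay, a 2.0-fold lower number (0.30 log units; within the scatter) from compound 2 to compound 1 and a 1.1-fold higher number (0.04 log units; within the scatter) from compound 3 to compound 4, 2.2-fold (0.34 log units) apart, within the scatter of two such steps. This shows that on both cores shown the change gives a step within the scatter, but with only two pairs, and with steps this small, it does not show that the change would read the same on other cores, nor does it give the change a direction.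

The compounds shown leave open how this carbonyl carbon would respond to groups further from these two, such as a longer alkyl chain on the amide nitrogen or a carboxylic acid in place of the amide. They also leave open whether a step beyond the scatter could be reached at this place on either core, and whether any such step would carry from one core to the other.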